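A few compounds are considered here, and "the series" means these few. Any claim that something is new, unique, unknown or untested is made for them only; others in the source may bear on it.

Three compounds share one core and differ in the group hanging from it. Compound 1 `Cc1ccc2nc(-c3ccccc3F)[nH]c(=O)c2c1` carries a fluoro, as does compound 2 `Cc1ccc2c(=O)[nH]c(-c3cccc(F)c3)nc2c1`, but the two have the same atoms joined differently, and the difference between the two cores is not broken down here. Compound 3 `Cc1ccc2c(=O)[nH]c(-c3cccc(OC(F)(F)F)c3)nc2c1` carries a trifluoromethoxy. In an assay on isolated protein for inhibition of DNA topoisomerase 1 (Homo sapiens), with a stated time of 30 min, tested at 100 uM (on this read-out lower numbers stand for a weaker effect and higher numbers for a stronger effect at the one concentration tested), compound 1 gives 67.9%. In this assay compound 2 gives 77.5% and compound 3 gives 77.2%; all three numbers lie within the scatter of one another, so no order among them can be claimed. The change trifluoromethoxy in place of fluoro on an aromatic carbon gave a number 0.3 percentage points lower from compound 2 to compound 3 (within the scatter). Compound 4 `Cc1ccc2nc(-c3ccccc3OC(F)(F)F)[nH]c(=O)c2c1` has not yet been measured. It arises from compound 1 by the same kind of change, (trifluoromethoxy in place of fluoro on an aromatic carbon), though here the place is ortho to a large group rather than meta to a large group. The step is expected to be small, a number 0.1 percentage points higher from compound 1 to compound 4 (within the scatter). That expectation rests on the flat earlier step, a number 0.3 percentage points lower from compound 2 to compound 3 (within the scatter), and on the starting value of compound 1, 67.9%. Compound 4 is thus estimated to give 68% in this assay, with an expected range from 55% to 80%.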

Compound 4, a percentage reported as inhibition, at one concentration (the size of the read-out at that concentration, not a potency): 66.9%
Compound 4: middle estimate off by 1.1 percentage points, on the high side; measured number inside the range.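

In this assay, putting trifluoromethoxy in place of fluoro on the core of compound 1 gave a number 1 percentage points lower from compound 1 to compound 4 (within the scatter). Set beside the earlier case, the change reads the same on both cores, even though the place on the ring is not the same: the same change on two cores in this assay, a number 0.3 percentage points lower (within the scatter) from compound 2 to compound 3 and a number 1 percentage points lower (within the scatter) from compound 1 to compound 4, 0.7 percentage points apart, within the scatter of two such steps. Going by these compounds alone, this shows only that a swap with no readable effect on one core also had no readable effect on the other; with just two pairs, core and place cannot be told apart, and it does not show that a change with a clear effect would carry over in the same way.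

The compounds shown have only fluoro or trifluoromethoxy on that ring, so it remains open whether an amine, a carboxylic acid or a longer chain there would shift the number beyond the scatter. Also open, on these data alone, is how each group would read at the other place on the same core.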